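Trimming the Ether Tail of a Carbamate Inhibitor

The compounds below may be only part of what the source reports. "The series", "measured", "known", "first", "only" and "open" are said of these compounds alone.

Compound 1 `CN1CCC(c2ccc3c(c2)oc(=O)n3C(=O)NCCOCc2ccccc2)CC1` is the strongest of the three compounds measured here in an assay on HEK293 cells for inhibition of acid ceramidase (Homo sapiens), read by fluorescence, with stated times of 10 min and 3 h (a lower number here means a stronger inhibitor, a higher number a weaker inhibitor), where compound 1 gives 215 nM. Compound 2 `CC(C)CNC(=O)n1c(=O)oc2ccc(C3CCN(C)CC3)cc21` gives 295 nM, a number within the scatter of that of compound 1, whereas compound 3 `CC(C)CNC(=O)n1c(=O)oc2cc(C3CCCN(C)C3)ccc21` gives 1750 nM, well beyond it. The new compound 4 `CCOCCNC(=O)n1c(=O)oc2cc(C3CCN(C)CC3)ccc21` keeps the shared core of compound 1 and differs only in its ether tail: methyl in place of phenyl on a saturated chain carbon bound to an oxygen on a saturated carbon. Going by the values given here, no measured pair shows this exact change, so the expected step is uncertain; a small weakening, close to the edge of the usual scatter, seems the likeliest outcome. Compound 4 is therefore estimated at 400 nM, with a plausible range from 150 nM to 1100 nM, a step of a 1.9-fold higher number from compound 1 to compound 4 (0.27 log units; within the scatter).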

Compound 4, half-maximal inhibitory concentration: 1050 nM
Compound 4: middle estimate off by 2.6-fold (0.42 log units), on the low side, and the stated range covers the measured number.
By their numbers in this assay, from the lowest: compounds 1 and 2 (each within the scatter of the next); then compounds 4 and 3 (each within the scatter of the next).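

Replacing phenyl with methyl on the ether tail gives a 4.9-fold higher number from compound 1 to compound 4 (0.69 log units; beyond the scatter) in this assay, so this position does not tolerate the change without loss. The earlier compounds shown here held no pair that tested this tail, and this step shows that the benzyloxy end matters more than ethoxy can make up for. Nothing measured here explains the loss. Still open, going by these compounds, is whether the aromatic ring itself is needed or whether size alone counts. A cyclohexyl ring in place of phenyl, or a longer chain such as butoxy, would separate those two readings.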